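This account rests on a few compounds, and the source may have more. Where it says the series, first, only, none or still open, it means among the compounds named here.

In an ADME assay on HepG2 2.2.15 cells (Homo sapiens) for cytotoxicity, read by MTT assay, with stated times of 48 h and 9 days (a higher number here means that more compound is tolerated, a lower number that less compound is tolerated), three compounds sharing one core have been measured. Compound 1 `COc1ccc2c(=O)c(/C=C/C(=O)NCc3ccccc3)coc2c1`, with a benzyl group on the amide nitrogen, gives 376000 nM. Compound 2 `COc1cccc(NC(=O)/C=C/c2coc3cc(OC)ccc3c2=O)c1`, with 3-methoxyphenyl in that place, gives 1130000 nM. Compound 3 `COc1ccc2c(=O)c(/C=C/C(=O)NCc3ccccc3F)coc2c1`, with 2-fluorobenzyl there, gives 146000 nM, the lowest of the three numbers.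

Compound 4 `COc1ccc2c(=O)c(/C=C/C(=O)NCc3ccc(F)cc3F)coc2c1` differs from compound 3 in one place: fluoro in place of hydrogen on an aromatic carbon. A fluoro replaces hydrogen on an aromatic carbon, meta to a fluoro group and para to a large group, so 2-fluorobenzyl becomes 2,4-difluorobenzyl.

Among the measured compounds shown here, the closest precedent is the same kind of swap, a 2.6-fold lower number from compound 1 to compound 3 (0.41 log units; beyond the scatter), a modest step. That step made the 2-fluorobenzyl group rather than the 2,4-difluorobenzyl group, so this single case is only a weak guide. The other two steps, a 3.0-fold higher number from compound 1 to compound 2 (0.48 log units; beyond the scatter) and a 7.7-fold lower number from compound 2 to compound 3 (0.89 log units; beyond the scatter), exchange the whole group on the nitrogen and say little about adding one fluoro.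

A smaller move in the same direction is therefore expected, and the estimated step is a 1.3-fold lower number from compound 3 to compound 4 (0.12 log units; within the scatter). For compound 4 the estimated value is 110000 nM, with an expected range from 45000 nM to 270000 nM.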

Compound 4, half-maximal cytotoxic concentration: 79300 nM
Compound 4: middle estimate off by 1.4-fold (0.14 log units), on the high side; the measured number falls inside the stated range.
By their numbers in this assay, from the lowest: compounds 4 and 3 (each within the scatter of the next); then compound 1; then compound 2.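

The added fluoro at this place, meta to a fluoro group and para to a large group, gives a 1.8-fold lower number from compound 3 to compound 4 (0.27 log units; within the scatter) in this assay, so this second fluoro cannot be told apart from the repeat variation of the measurement. Only the larger comparisons clear the scatter: taking the phenyl of the benzyl group to 2,4-difluorophenyl gives a 4.7-fold lower number from compound 1 to compound 4 (0.68 log units; beyond the scatter), and exchanging the 3-methoxyphenyl group on the amide nitrogen for 2,4-difluorobenzyl gives a 14-fold lower number from compound 2 to compound 4 (1.15 log units; beyond the scatter). In these three compounds, then, compound 4 and compound 3 stand together at the low end of the series, and nothing shown gives a measured reason for how a fluoro acts on this number.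

The compounds shown leave open whether a chloro, a methoxy or an amine at this same place would shift the number differently from the fluoro. They also cannot say whether this fluoro would give a clearer step on the benzyl group of compound 1, where no other fluoro is present.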